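Replacing the aryl group of compound 2

This account rests on a few compounds, and the source may have more. Where it says the series, first, only, none or still open, it means among the compounds named here.

Within the data shown here, in a functional assay on KB cells (Homo sapiens) for antiproliferative activity, read by sulforhodamine B assay, with a stated time of 3 days (a lower number here means that less compound is needed, a higher number that more compound is needed for the effect), compound 2 `CCC1=C(O)c2c(oc(-c3ccc(O)c(C)c3C)cc2=O)C(CC)(CC)C1=O` gives 6.5 uM, the only full number so far. Compound 1 `CCC1=C(O)c2c(oc(-c3ccc(COC)cc3)cc2=O)C(CC)(CC)C1=O` reads > 52.4 uM, which is a limit and not a number. Among the measured compounds shown here, the one measured step is an at least 8.0-fold lower number from compound 1 to compound 2 (0.90 log units; beyond the scatter), with 4-hydroxy-2,3-dimethylphenyl in place of 4-(methoxymethyl)phenyl. Compound 3 `CCC1=C(O)c2c(oc(-c3cc(C)ccc3F)cc2=O)C(CC)(CC)C1=O` has 2-fluoro-5-methylphenyl in place of 4-hydroxy-2,3-dimethylphenyl on an aromatic carbon. That removes the group tied to the gain in an at least 8.0-fold lower number from compound 1 to compound 2 (0.90 log units; beyond the scatter), so a higher number is expected in this assay. The expected step is a 3.1-fold higher number from compound 2 to compound 3 (0.49 log units; beyond the scatter). Compound 3 is estimated at 20 uM, within 6 uM to 60 uM.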

Compound 3, concentration for half-maximal effect: 47.3 uM
Estimate against measurement, compound 3: 2.4-fold (0.37 log units) below; measured number inside the range.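

At this aromatic carbon next to the ring oxygen, not every substituted phenyl holds the number of compound 2. With 2-fluoro-5-methylphenyl in place of 4-hydroxy-2,3-dimethylphenyl, the step in this assay is a 7.3-fold higher number from compound 2 to compound 3 (0.86 log units; beyond the scatter). With 2-fluoro-5-methylphenyl in place of 4-(methoxymethyl)phenyl, the step is an at least 1.1-fold lower number from compound 1 to compound 3 (0.04 log units; that floor lies within the scatter). Compound 1 carries a limit and not a number: the limit of > 52.4 uM in this assay, at which 1 of the 3 values shown sits.

The hydroxy group, the methyl groups and the fluorine all change together, so the compounds shown do not tell which of them matters. From the compounds shown here alone, how an amine or a carboxylic acid on the phenyl ring would read also stays open.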